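The source may hold more compounds than are shown below. What is called first, only, known or untested is meant among the compounds shown, and "the series" means these compounds.

In a toxicity assay on HepG2 cells (Homo sapiens) for inhibition, read by CellTiter-Glo, with a stated time of 48 h (a lower number here means a stronger inhibitor, a higher number a weaker inhibitor), compound 1 `COc1cccc(NC(=O)COc2cc(C)nc3ccc(OC)cc23)c1` gives only a limit, > 100000 nM. Going by the values given here, compound 2 `COc1ccc2nc(C)cc(OCC(=O)Nc3ccc(Br)c(C)c3)c2c1` gives 15900 nM, the single number in hand. Among the compounds with values here, the only other value, that of compound 1, is the limit (the limit of > 100000 nM in this assay, at which 1 of the 2 values shown sits). Within the data shown here, the measured step of an at least 6.2-fold lower number from compound 1 to compound 2 (0.79 log units; beyond the scatter) is the one change seen on an amide-type nitrogen, and it bears on the present step only loosely. Compound 3 `COc1ccc2nc(C)cc(OCC(=O)Nc3ccc(Cl)cc3)c2c1` differs from compound 2 by 4-chlorophenyl in place of 4-bromo-3-methylphenyl on an amide-type nitrogen. For compound 3 a somewhat higher number is expected, a 2.2-fold higher number from compound 2 to compound 3 (0.34 log units; beyond the scatter), giving an estimate of 35000 nM with a range from 10000 nM to 120000 nM.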

Compound 3, half-maximal inhibitory concentration: > 100000 nM
Compound 3: a limit, no number; the forecaster's own chance of this, stated with the estimate: 35%; at least 2.8-fold (0.45 log units) between middle value and limit.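

In this assay, the new result adds a second replacement for the 4-bromo-3-methylphenyl group on the amide-type nitrogen: 4-chlorophenyl in its place gives an at least 6.2-fold higher number from compound 2 to compound 3 (0.79 log units; beyond the scatter). Compound 2 remains the only one of the three with a number, while compound 1 and compound 3 both end at a limit: the limit of > 100000 nM in this assay, at which 2 of the 3 values shown sit.

The step from compound 1 to compound 3 cannot be read, as both of its values are limits. Still open, from the compounds shown here alone, is how a 4-bromophenyl or a 3-methylphenyl group on the same nitrogen would read, and so which part of the 4-bromo-3-methylphenyl group goes with the lower number.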